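Difluorophenyl in Place of Methylphenyl on a Shared Core

The source may hold more compounds than are shown below. What is called first, only, known or untested is meant among the compounds shown, and "the series" means these compounds.

Measured so far:
compound 1, `COc1cc2c(Oc3ccc(NC(=O)c4nccc(-c5ccc(C)cc5)n4)cc3F)ccnc2cc1OCCCN1CCCCC1`, 1140 nM;
compound 2, `COc1cc2c(Oc3ccc(NC(=O)c4nccc(-c5ccc(C)cc5)n4)cc3F)ccnc2cc1OCCCN1CCN(C)CC1`, "not determined" (no result reported).

Compound 1 was tested in a functional assay on U-87MG ATCC cells (Homo sapiens) for cytotoxicity, read by MTT assay, with a stated time of 72 h (on this read-out lower numbers stand for stronger inhibition and higher numbers for weaker inhibition), and gives 1140 nM. Among the compounds with values here, compound 2 shares the whole of that structure apart from the group at the end of the three-carbon chain, yet for compound 2 the entry in this assay reads "not determined" (no result reported), so where it stands can only be inferred from compound 1, which is the one value on hand.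

Compound 3, `COc1cc2c(Oc3ccc(NC(=O)c4nccc(-c5ccc(F)cc5F)n4)cc3F)ccnc2cc1OCCCN1CCN(C)CC1`, is the next member of the series and has not been measured. It differs from compound 2 in a single place: 2,4-difluorophenyl in place of 4-methylphenyl on an aromatic carbon. Within the data shown here, because no pair of measured compounds differs in one place, there is no measured step to lean on for the size or the direction of this change. The expectation rests only on compound 1 giving 1140 nM and on the closeness of compound 2 to it. A step of no more than the usual scatter in this assay is expected, in either direction. For compound 3 the estimated value in this assay is 800 nM, with a range from 200 nM to 3500 nM.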

Compound 3, half-maximal inhibitory concentration: 780 nM
Compound 3: the middle estimate sits 1.0-fold (0.01 log units) above what was measured; the measured number falls inside the stated range.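

No new step can be read here: compound 2 has no number to set against compound 3, and compound 1 differs from compound 3 in more than one place. The compounds shown leave open what 2,4-difluorophenyl in place of 4-methylphenyl does in this assay. No supporting evidence bears on this result.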